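Working notes: the ethyl step on compound 3

A few compounds are considered here, and "the series" means these few. Any claim that something is new, unique, unknown or untested is made for them only; others in the source may bear on it.

Measured in an ADME assay on A549 cells (Homo sapiens) for cytotoxicity, read by MTT assay (a higher number here means that more compound is tolerated, a lower number that less compound is tolerated), so far:
compound 1 `CCCCCCCCCCNc1nc(=O)n([C@H]2C[C@H](O)[C@@H](CO)O2)cc1C` gives 156000 nM
compound 2 `CCCCCCCCCCCCNc1nc(=O)n([C@H]2C[C@H](O)[C@@H](CO)O2)cc1C` gives 158000 nM
compound 3 `CCCCCCCCCCNc1nc(=O)n([C@H]2C[C@H](OC(=O)OCCOCCOCCO)[C@@H](CO)O2)cc1C` gives 90000 nM

Compound 3, at 90000 nM, lies within the scatter of both compound 1 and compound 2, so the three values set up no order. The next structure is compound 4 `CCCCCCCCCCCCNc1nc(=O)n([C@H]2C[C@H](OC(=O)OCCOCCOCCO)[C@@H](CO)O2)cc1C`, still to be measured in this assay and separated from compound 3 by a single difference: ethyl in place of hydrogen on a saturated chain carbon, ten or more bonds along the chain from a nitrogen on an aromatic ring and no other change.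

Among the measured compounds shown here, two measured steps bear on this. The same replacement, ethyl in place of hydrogen, gave a 1.0-fold higher number from compound 1 to compound 2 (0.01 log units; within the scatter) on the pair lacking the larger group on the oxygen. That larger group itself gave a 1.7-fold lower number from compound 1 to compound 3 (0.24 log units; within the scatter) and so also stayed inside the scatter. For the measured compounds named here, no measured pair tests the ethyl replacement with the larger group present, so the expectation rests on one step, that of compound 2 from compound 1.

On that basis no step beyond the scatter is expected, in either direction. The expected step is a 1.0-fold higher number from compound 3 to compound 4 (0.01 log units; within the scatter) and is estimated to be negligible. For compound 4 the estimated value is 92000 nM, with an expected range from 55000 nM to 150000 nM in this series.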

Compound 4, half-maximal cytotoxic concentration: 90000 nM
Beside the measured number, compound 4's estimate is 1.0-fold (0.01 log units) above it, within the range that was stated.
By their numbers in this assay, from the lowest: compounds 3, 4, 1 and 2 (each within the scatter of the next).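

In this assay, the ethyl replacement had been read only on the pair without the larger group on the oxygen; with that group present, the reading is no change at the digits printed from compound 3 to compound 4 (within the scatter), and the two readings agree: the same change on two cores in this assay, a 1.0-fold higher number (0.01 log units; within the scatter) from compound 1 to compound 2 and no change at the digits printed (within the scatter) from compound 3 to compound 4, 1.0-fold (0.01 log units) apart, within the scatter of two such steps

The larger group on the oxygen can now also be read on the second core, where the reading is a 1.8-fold lower number from compound 2 to compound 4 (0.24 log units; within the scatter), and this agrees with its step on the first core: the same change on two cores in this assay, a 1.7-fold lower number (0.24 log units; within the scatter) from compound 1 to compound 3 and a 1.8-fold lower number (0.24 log units; within the scatter) from compound 2 to compound 4, 1.0-fold (0.01 log units) apart, within the scatter of two such steps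

Neither change gives a step beyond the scatter on either core, so within these four compounds the effect of the ethyl replacement shows no dependence on the group on the oxygen, nor the reverse.

The compounds shown do not tell whether an amine or a carboxylic acid at this place on the chain, or a longer chain, would give a step beyond the scatter in this assay. As far as these compounds go, it also remains open whether a different group on the oxygen, such as a simple acetyl, would stay within the scatter of compound 1.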